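Removing the methyl from the indole nitrogen of a weak cytotoxin

This account rests on a few compounds, and the source may have more. Where it says the series, first, only, none or still open, it means among the compounds named here.

Measured compounds:
compound 1, `COc1ccc2c(c1)c(/C=N\NC(=O)c1c[nH]c3ccc(Br)cc13)cn2Cc1ccc(Cl)cc1`, 26300 nM
compound 2, `COc1ccc2c(c1)c(/C=N\NC(=O)c1cn(C)c3ccccc13)cn2Cc1ccc(Cl)cc1`, 56400 nM

Compound 2 has the highest of the two numbers recorded in a functional assay on MIA PaCa-2 cells (Homo sapiens) for cytotoxicity; on this read-out lower numbers stand for stronger inhibition and higher numbers for weaker inhibition; its nearest neighbour is compound 1, which gives 26300 nM, and the step of a 2.1-fold higher number from compound 1 to compound 2 (0.33 log units; beyond the scatter) lies beyond the scatter. Compound 3, `COc1ccc2c(c1)c(/C=N\NC(=O)c1c[nH]c3ccccc13)cn2Cc1ccc(Cl)cc1`, is not yet measured. It differs from compound 2 by hydrogen in place of methyl on an aromatic nitrogen, so the ring in question is the same one that carries the bromine in compound 1 and the methyl in compound 2.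

For the measured compounds named here, only one measured step bears on this change, and only indirectly: a 2.1-fold higher number from compound 1 to compound 2 (0.33 log units; beyond the scatter), which swaps both the bromine and the methyl at once, a modest rise. Going by the values given here, no measured pair isolates the methyl on the aromatic nitrogen alone. Compound 3 therefore cannot be tied to either neighbour with confidence; it is expected to sit near compound 2, or somewhat lower, as a small step of a 1.4-fold lower number from compound 2 to compound 3 (0.15 log units; within the scatter) that may not exceed the scatter. The estimate for compound 3 in this assay is 40000 nM, with a range from 15000 nM to 100000 nM.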

Compound 3, half-maximal inhibitory concentration: 26700 nM
Beside the measured number, compound 3's estimate is 1.5-fold (0.18 log units) above it; low and high end bracket the measured number.
By their numbers in this assay, from the lowest: compounds 1 and 3 (each within the scatter of the next); then compound 2.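

In this assay, the new compound separates the two changes on the indole. Hydrogen in place of methyl on the aromatic nitrogen gives a 2.1-fold lower number from compound 2 to compound 3 (0.32 log units; beyond the scatter) as a modest step beyond the scatter, which shows that this nitrogen is sensitive to the change on its own, at least in this one pair, while hydrogen in place of bromo on an aromatic carbon gives a 1.0-fold higher number from compound 1 to compound 3 (0.01 log units; within the scatter) and stays within the scatter, so the bromine has no readable effect in this series. Nothing available here explains why the methyl on the nitrogen matters while the bromine does not.

The compounds shown leave open whether the step belongs to methyl in particular or to any group on this aromatic nitrogen, such as an ethyl, an acetyl or a longer chain. They also leave open whether the carbon that carries the bromine in compound 1 would stay as silent with a different group there, such as a methoxy, an amine or a carboxylic acid.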